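The source may hold more compounds than are shown below. What is called first, only, known or untested is meant among the compounds shown, and "the series" means these compounds.

Measured compounds:
- compound 1, `C/C=C1/[C@H](O[C@@H]2O[C@H](CO)[C@@H](O)[C@H](O)[C@H]2O)OC=C(C(=O)OC)[C@H]1CC(=O)OCCC1CCCCC1`: 2000 nM
- compound 2, `C/C=C1/[C@H](O[C@@H]2O[C@H](COC(C)=O)[C@@H](OC(C)=O)[C@H](OC(C)=O)[C@H]2OC(C)=O)OC=C(C(=O)OC)[C@H]1CC(=O)SCCc1ccccc1`: > 15000 nM, a limit
- compound 3, `C/C=C1/[C@H](O[C@@H]2O[C@H](COC(C)=O)[C@@H](OC(C)=O)[C@H](OC(C)=O)[C@H]2OC(C)=O)OC=C(C(=O)OC)[C@H]1CC(=O)OCCCC`: > 15000 nM, a limit

Among the compounds with values here, in a functional assay on SK-BR-3 cells (Homo sapiens) for antiproliferative activity, read by MTT assay, with a stated time of 72 h (on this read-out higher numbers stand for weaker inhibition and lower numbers for stronger inhibition), compound 1 gives 2000 nM, the only number among the three values shown. For compound 2 the value > 15000 nM is a limit of the assay, not a number. For compound 3 likewise > 15000 nM is a limit. Accordingly the one step between measured compounds that differ in one place, a step that the two limits leave unreadable from compound 2 to compound 3, cannot be read in size.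

Compound 4, `C/C=C1/[C@H](O[C@@H]2O[C@H](CO)[C@@H](O)[C@H](O)[C@H]2O)OC=C(C(=O)OC)[C@H]1CC(=O)OCCc1ccc([N+](=O)[O-])cc1`, has not been measured in this assay. It differs from compound 1 by 4-nitrophenyl in place of cyclohexyl on a saturated chain carbon, two bonds along the chain from an oxygen next to a carbonyl group. Within the data shown here, no measured step touches this position, and the only evidence beyond compound 1 is the limit of > 15000 nM in this assay, at which 2 of the 3 values shown sit, which gives no size for any change. Compound 4 therefore shares the free sugar and the ester of compound 1, and its value is expected to stay close to that of compound 1, with a step of a 1.3-fold higher number from compound 1 to compound 4 (0.10 log units; within the scatter) that is not expected to exceed the scatter. Compound 4 is estimated at 2500 nM, within 800 nM to 8000 nM.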

Compound 4, half-maximal inhibitory concentration: > 20000 nM
Compound 4 gave a limit, no number; the forecaster's own chance of this, stated with the estimate: 15%; middle value at least 8.0-fold (0.90 log units) away from the limit.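

In this assay, 4-nitrophenyl in place of cyclohexyl on a saturated chain carbon, two bonds along the chain from an oxygen next to a carbonyl group, gives an at least 10-fold higher number from compound 1 to compound 4 (1.00 log units; beyond the scatter). Within the data shown here, this shows that, with the free sugar and the ester kept, the group at this place is not interchangeable, something no earlier readable step could show, as the one earlier step cannot be read. Compound 4 gives > 20000 nM, which is a limit of the assay and not a number.

The compounds shown leave open whether the change in the read-out goes with the aromatic ring itself or with the nitro group on it. A plain phenyl, 4-aminophenyl or 4-methoxyphenyl group at this place, on the free sugar, would separate the two.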